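From 4-ethylphenyl to cyclopentyl on the amine nitrogen

The source may report more compounds than this note shows. Statements on the series, on what has been measured and on what is new or still open speak of the compounds shown alone.

Of the compounds shown here, two with the shared core have been read in a functional assay on MCF7 cells (Homo sapiens) for inhibition, read by sulforhodamine B assay; a lower number here means a stronger inhibitor, a higher number a weaker inhibitor. Going by the values given here, compound 2 `CCc1ccc(NC2=CC(=O)c3nc4n(c3C2=O)[C@H]2OC[C@@H](O)[C@H]2OC4)cc1` gives 960 nM, the only actual number so far. Compound 1 `O=C1C=C(NC2CCCCC2)C(=O)c2c1nc1n2[C@H]2OC[C@@H](O)[C@H]2OC1` gives > 8000 nM, which is a limit of the assay and not a number. Among the compounds with values here, the one measured step is an at least 8.3-fold lower number from compound 1 to compound 2 (0.92 log units; beyond the scatter), with 4-ethylphenyl in place of cyclohexyl on an amine nitrogen.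

Compound 3 `O=C1C=C(NC2CCCC2)C(=O)c2c1nc1n2[C@H]2OC[C@@H](O)[C@H]2OC1` has not yet been measured in this assay. Its difference from compound 2 is cyclopentyl in place of 4-ethylphenyl on an amine nitrogen. The entering cyclopentyl is closer to the cyclohexyl of compound 1 than to 4-ethylphenyl, so an at least 8.3-fold lower number from compound 1 to compound 2 (0.92 log units; beyond the scatter) is the step that bears on this change. A step of similar size is expected, but in the opposite direction, towards a higher number, although this rests on a single pair. The expected change is a 7.3-fold higher number from compound 2 to compound 3 (0.86 log units; beyond the scatter). For compound 3 the estimate is 7000 nM, with an expected range of 2500 nM to 20000 nM.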

Compound 3, half-maximal inhibitory concentration: > 16000 nM
Compound 3 was reported as a limit; the forecaster's own chance of this, stated with the estimate: 55%; middle value at least 2.2-fold (0.35 log units) away from the limit.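

In this assay cyclopentyl in place of 4-ethylphenyl on the amine nitrogen gives an at least 16-fold higher number from compound 2 to compound 3 (1.22 log units; beyond the scatter) and so places a second non-aromatic ring on the same side as cyclohexyl, leaving 4-ethylphenyl as the only group among the three compounds shown with a readable number; none of the three goes against this. Compound 3 is reported as a limit of the assay and not as a number: the limit of > 16000 nM in this assay, at which 1 of the 3 values shown sits. Compound 1 is likewise reported as a limit and not as a number: the limit of > 8000 nM in this assay, at which 1 of the 3 values shown sits.

The step between cyclohexyl and cyclopentyl cannot be read, so these two compounds leave the effect of ring size among the non-aromatic groups open. Also open, on these data alone, is which part of 4-ethylphenyl carries the difference: an unsubstituted phenyl, a 4-methylphenyl or a benzyl on the same nitrogen would separate the aromatic ring from the ethyl chain and from its direct attachment to the amine nitrogen.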